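This account rests on a few compounds, and the source may have more. Where it says the series, first, only, none or still open, it means among the compounds named here.

Working notes on the series. Compound 1 `CC(C)(C)OC(=O)CNCc1ccc(Cl)cc1` gives "not determined" (no result reported) in a functional assay on HEK293 cells for agonist activity at nuclear receptor subfamily 1 group D member 1 (Homo sapiens), read by a luciferase reporter, with a stated time of 24 h; on this read-out lower numbers stand for an effect already at smaller amounts and higher numbers for an effect only at larger amounts of compound. Compound 2 `O=[N+]([O-])c1ccc(CN(Cc2ccc(Cl)cc2)Cc2ccc(C(F)(F)F)cc2)s1` gives 5500 nM in this assay. Compound 3 `CC(C)(C)OC(=O)N1CCC(CN(Cc2ccc(Cl)cc2)Cc2ccc([N+](=O)[O-])s2)C1` gives 1800 nM in this assay, the lower of the two numbers reported so far; the gap to compound 2 lies beyond the usual scatter. Compound 4 `CS(=O)(=O)N1CCC(CN(Cc2ccc(Cl)cc2)Cc2ccc([N+](=O)[O-])s2)C1` has not yet been measured. It differs from compound 3 in one place: methylsulfonyl in place of tert-butoxycarbonyl on an amine nitrogen in a ring. Going by the values given here, no measured pair shows a step of this kind, so the expected size of the change rests on the structural change alone. The step of a 1.4-fold higher number from compound 3 to compound 4 (0.14 log units; within the scatter) is expected to be small, with no direction established beyond the scatter. For compound 4 the estimate in this assay is 2500 nM, with a range from 800 nM to 8000 nM.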

Compound 4, half-maximal effective concentration: 570 nM
Estimate against measurement, compound 4: 4.4-fold (0.64 log units) above; the whole stated range lies above it.
By their numbers in this assay, from the lowest: compound 4; then compound 3; then compound 2.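

Going by these compounds alone, on the amine nitrogen of the five-membered non-aromatic ring, methylsulfonyl in place of tert-butoxycarbonyl gives a 3.2-fold lower number from compound 3 to compound 4 (0.50 log units; beyond the scatter) in this assay and is the first step that can be read at this position. The smaller group keeps the counts of hydrogen-bond donors and acceptors unchanged, so the number moves without any change in those counts. No measurement shown accounts for the step. From the compounds shown here alone, it remains open whether the lower number belongs to methylsulfonyl itself or to the loss of tert-butoxycarbonyl, a question that an acetyl group or the free ring amine on this nitrogen would address.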